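Compound 2 to compound 4: a 2-cyanoethenyl swap

The source may hold more compounds than are shown below. What is called first, only, known or untested is meant among the compounds shown, and "the series" means these compounds.

Compound 1 `C=C[C@@](C)(/C=C/c1ccc(OC)cc1)CCC=C(C)C`: > 36600 nM
Compound 2 `C=C[C@@](C)(/C=C/c1ccc(O)cc1)CCC1OC1(C)C`: > 36600 nM
Compound 3 `C=C[C@@](C)(/C=C/c1ccc(O)cc1)CC/C=C/C(=O)OCc1ccccc1`: > 36600 nM

These entries come from an ADME assay on HEK293 cells (Homo sapiens) for cytotoxicity, with a stated time of 72 h (on this read-out higher numbers stand for an effect only at larger amounts of compound and lower numbers for an effect already at smaller amounts), and the record shows (the limit of > 36600 nM in this assay, at which 3 of the 3 values shown sit). Compound 2 stands only at a limit, > 36600 nM. The structural change leading to compound 4 `C=C[C@@](C)(/C=C/c1ccc(O)cc1)CC/C=C/C#N` is 2-cyanoethenyl in place of 3,3-dimethyloxiran-2-yl on a saturated chain carbon, three bonds along the chain from two double-bonded chain carbons: 2-cyanoethenyl in place of 3,3-dimethyloxiran-2-yl on a saturated chain carbon. Among the measured compounds shown here, no measured step gives a size for such a change. In this assay, no step beyond the scatter is expected, in either direction, and this expectation rests on the limit of compound 2 at > 36600 nM. The estimated change is an at least 1.2-fold lower number from compound 2 to compound 4 (0.08 log units; that floor lies within the scatter). Compound 4 is expected at about 30000 nM, with an estimated range from 10000 nM to 60000 nM.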

Compound 4, half-maximal effective concentration: > 36600 nM
Compound 4: only a limit was reported; the forecaster's own chance of this, stated with the estimate: 75%; at least 1.2-fold (0.08 log units) between middle value and limit.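

Compound 2 and compound 4 each stand only at a limit, so no step can be read between them: the limit of > 36600 nM in this assay, at which 4 of the 4 values shown sit.

The compounds shown leave open whether the 2-cyanoethenyl swap changes cytotoxicity at all, since none gives a number past that limit.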